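Changing One Group on the Outer Ring

The source may report more compounds than this note shows. Statements on the series, on what has been measured and on what is new or still open speak of the compounds shown alone.

Compound 1 `COc1cccc(CNCCCNc2ccnc3cc(-c4ccc(C(F)(F)F)cc4)ccc23)c1O` — 9.47
Compound 2 `CC(C)(C)c1ccc(Oc2ccc3c(NCCCNCc4ccco4)ccnc3c2)cc1` — 9.28
Compound 3 `FC(F)(F)c1ccc(-c2ccc3c(NCCCNCc4ccco4)ccnc3c2)cc1` — 9.47

All three were measured in a physicochemical assay for acid dissociation. Compound 1 matches compound 3 at the digits shown, and compound 2 sits within the scatter of both, so the three numbers cannot be told apart. Compound 4 `COc1cccc(CNCCCNc2ccnc3cc(-c4ccc(F)cc4)ccc23)c1O` has not been measured. It differs from compound 1 in one place: fluoro in place of trifluoromethyl on an aromatic carbon, which read one bond further out is 4-(trifluoromethyl)phenyl becoming 4-fluorophenyl. Among the measured compounds shown here, the only measured single change, no change at the digits printed from compound 1 to compound 3 (within the scatter), swaps a group on a saturated chain carbon bound to an amine nitrogen and gave no change. For the measured compounds named here, no measured step touches the ring altered here, so the step expected is no change at the digits printed from compound 1 to compound 4 (within the scatter), nothing beyond the scatter. Compound 4 is therefore estimated at 9.47, between 9.15 and 9.8.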

Compound 4, acid dissociation constant: 9.47
Compound 4: middle estimate and measured number agree at the digits printed, within the range that was stated.
By their numbers in this assay, from the lowest: compounds 2, 1, 3 and 4 (each within the scatter of the next).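

In this assay, among the compounds shown here, replacing trifluoromethyl with fluoro on the outer aromatic ring gives no change at the digits printed from compound 1 to compound 4 (within the scatter), the first measured step at this ring rather than on the chain. A group of four heavy atoms can therefore give way to a single fluorine here with no change beyond the scatter. No available evidence explains this outcome. Still open, from the compounds shown here alone, is whether a carboxylic acid or an amine in this same place would also leave the number within the scatter. Going by these compounds, it is also open whether the same swap would give the same result alongside the furan-2-yl group of compound 3.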